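This account rests on a few compounds, and the source may have more. Where it says the series, first, only, none or still open, it means among the compounds named here.

In an assay on isolated protein for binding affinity to histamine H2 receptor (Homo sapiens) (a higher number here means a weaker inhibitor, a lower number a stronger inhibitor), two compounds have been measured so far. Compound 1 `CCCCCC(=O)c1ccc(OCCCN2CCN(C(=O)c3c[nH]cn3)CC2)cc1` gives 19500 nM. Compound 2 `CCOC(=O)N1CCN(CCCOc2ccc(C(C)=O)cc2)CC1` gives 39800 nM, the higher of the two numbers; its gap to compound 1 lies beyond the scatter of repeated measurements, so compound 2 is the weaker binder of the pair. Compound 3 `CCOC(=O)N1CCN(CCCOc2ccc(C(=O)c3ccc(C(C)(C)C)cc3)cc2)CC1` has not yet been measured. It differs from compound 2 in one place: 4-(tert-butyl)phenyl in place of methyl on a carbonyl carbon. Among the measured compounds shown here, no measured pair shows this exact change, so any expectation rests only on the two numbers above. Going from compound 2 to compound 3, a moderate drop in the number is expected, a 4.0-fold lower number from compound 2 to compound 3 (0.60 log units; beyond the scatter), though the uncertainty is wide. For compound 3 the estimated value in this assay is 10000 nM, with a likely range from 2000 nM to 40000 nM.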

Compound 3, inhibition constant: 1550 nM
The estimate for compound 3 lay 6.5-fold (0.81 log units) above the measured number, outside the stated range (below it).
By their numbers in this assay, from the lowest: compound 3; then compound 1; then compound 2.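

Putting 4-(tert-butyl)phenyl in place of methyl on a carbonyl carbon gives a 26-fold lower number from compound 2 to compound 3 (1.41 log units; beyond the scatter) in this assay, so at this position a much larger group bearing an aromatic ring goes with a lower number, not a higher one. The two earlier compounds differ in more than one place, so they could not show what a change at this position alone does. Nothing measured here explains why the number falls so far.

This single step brings in the ring and the tert-butyl group together, so the compounds shown do not separate what each part contributes. From the compounds shown here alone, whether a plain phenyl or a cyclohexyl group on the same carbonyl carbon would give a similarly low number remains open.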